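The source may hold more compounds than are shown below. What is called first, only, known or untested is meant among the compounds shown, and "the series" means these compounds.

Measured so far in a physicochemical assay for solubility, at pH 7.4; on this read-out higher numbers stand for higher solubility and lower numbers for lower solubility:

- Compound 1 `O=C(NCc1ccc(-c2noc(CCC3CC3)n2)cc1)[C@H]1NCC[C@@H]1O`: > 50 ug/mL (a limit of the assay)
- Compound 2 `CCCCCCCc1nc(-c2ccc([C@@H](C)NC(=O)[C@H]3NCC[C@@H]3O)cc2)no1`: 27 ug/mL

Compound 1 gives only a limit and no number: it stands on (the limit of > 50 ug/mL in this assay, at which 1 of the 2 values shown sits). Any step away from compound 1 is therefore anchored to a limit, not to a fixed point.

The next compound to read is compound 3 `O=C(NCc1ccc(-c2noc(C3CCCCC3)n2)cc1)[C@H]1NCC[C@@H]1O`, which carries cyclohexyl in place of 2-cyclopropylethyl on an aromatic carbon of a five-membered aromatic ring with 2 nitrogen and 1 oxygen (cyclohexyl in place of 2-cyclopropylethyl on an aromatic carbon). Within the data shown here, no pair of measured compounds differs in one place, so the size of this change has no direct precedent. Among the measured compounds shown here, the only number available as a guide is that of compound 2, which gives 27 ug/mL.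

No change beyond the usual scatter is expected, and the estimate is an at least 1.2-fold lower number from compound 1 to compound 3 (0.09 log units; that floor lies within the scatter). Compound 3 may also come back as a limit rather than a number. For compound 3 the expected value is 40 ug/mL, with an estimated range from 15 ug/mL to 80 ug/mL.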

Compound 3, solubility: > 50 ug/mL
Compound 3: no number, only a limit (the forecaster's own chance of this, stated with the estimate: 35%); middle value at least 1.2-fold (0.09 log units) from the limit.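

In this assay compound 1 and compound 3 each give only a limit of the assay and no number, so no step between them can be read: the limit of > 50 ug/mL in this assay, at which 2 of the 3 values shown sit.

The compounds shown leave open whether cyclohexyl and 2-cyclopropylethyl on the shared core differ at all in this assay, and by how much.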